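Chloro to Nitro on a Dopamine Transporter Ligand

A few compounds are considered here, and "the series" means these few. Any claim that something is new, unique, unknown or untested is made for them only; others in the source may bear on it.

Three compounds carry a shared core with a methyl ester next to an aryl group. Among the compounds with values here, compound 1 `COC(=O)C1=C(c2ccc(OC(F)(F)F)cc2)CCC1` is the weakest of the two numbers known: in an assay on COS-1 cells for displacement of a labelled ligand from sodium-dependent dopamine transporter (Homo sapiens) (on this read-out lower numbers stand for stronger inhibition and higher numbers for weaker inhibition), compound 1 gives 2650000 nM. Compound 2 `COC(=O)C1=C(c2ccc(S(C)(=O)=O)cc2)CCC1` in this assay gives "not determined" (no result reported). Compound 3 `COC(=O)C1=C(c2cccc(Cl)c2)CCCC1` stands lowest of the two numbers; in this assay compound 3 gives 22000 nM, and its nearest neighbour is compound 1, whose number is higher by a gap well beyond the scatter.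

Compound 4 `COC(=O)C1=C(c2cccc([N+](=O)[O-])c2)CCCC1` differs from compound 3 in one place: nitro in place of chloro on an aromatic carbon. Within the data shown here, no pair of measured compounds shows this kind of swap, so nothing measured here tells its size. With the two rings and the ester unchanged, the expected step in this assay from compound 3 to compound 4 is no change at the digits printed from compound 3 to compound 4 (within the scatter), within the scatter. Compound 4 is therefore estimated at 22000 nM, with a range from 6000 nM to 90000 nM.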

Compound 4, inhibition constant: 239000 nM
The estimate for compound 4 lay 11-fold (1.04 log units) below the measured number, outside the stated range (above it).
By their numbers in this assay, from the lowest: compound 3; then compound 4; then compound 1.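

In this assay, nitro in place of chloro on an aromatic carbon, meta to a large group, gives an 11-fold higher number from compound 3 to compound 4 (1.04 log units; beyond the scatter), a large step towards weaker inhibition. Within the data shown here, this is the first step that can be read with only one place changed, and it shows that inhibition at this position depends on which of these two groups is present, with chloro the better of the pair. Nothing given here explains why the two groups differ by this much.

The compounds shown leave open whether an amine, a carboxylic acid or a methoxy group at this position would stay close to chloro or fall as far as nitro. They also leave open whether the same swap would produce a step of this size on the core of compound 1.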